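Pentafluoroethyl in place of the hydroxy-bearing group

The compounds below may be only part of what the source reports. "The series", "measured", "known", "first", "only" and "open" are said of these compounds alone.

Three measured compounds share one core and differ only in the group on one aromatic carbon. Compound 1 `CS(=O)(=O)Nc1ccc(CNC(=O)c2ccc(N3CCCCC3)cc2)c(Cl)c1` gives 410 nM in an assay on HeLa cells for agonist activity at Bile acid receptor (Homo sapiens), read by a luciferase reporter, with a stated time of 24 h; on this read-out lower numbers stand for an effect already at smaller amounts and higher numbers for an effect only at larger amounts of compound. Compound 2 `CC(C)Oc1ccc(C(=O)NCc2ccc(NS(C)(=O)=O)cc2Cl)cc1` gives 400 nM in this assay, and a 1.0-fold lower number from compound 1 to compound 2 (0.01 log units; within the scatter). Compound 3 `CC(C)(O)c1ccc(C(=O)NCc2ccc(NS(C)(=O)=O)cc2Cl)cc1` gives 32 nM in this assay, the lowest of the three numbers; the steps are a 13-fold lower number from compound 1 to compound 3 (1.11 log units; beyond the scatter) and a 13-fold lower number from compound 2 to compound 3 (1.10 log units; beyond the scatter), so compound 3 stands clearly apart from the other two.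

Compound 4 `CS(=O)(=O)Nc1ccc(CNC(=O)c2ccc(C(F)(F)C(F)(F)F)cc2)c(Cl)c1` is not yet measured. Its change from compound 3 is 1,1,2,2,2-pentafluoroethyl in place of 1-hydroxy-1-methylethyl on an aromatic carbon. Both measured steps that end at compound 3 bear on this: each time 1-hydroxy-1-methylethyl replaced a group without a hydrogen-bond donor, the number fell by a large amount in this assay. Compound 4 walks this direction backwards, since the entering group carries neither donor nor acceptor, so a large rise in the number is expected, roughly back to the level of compound 1 and compound 2. The step is therefore estimated as a 16-fold higher number from compound 3 to compound 4 (1.19 log units; beyond the scatter) for compound 4. In this assay compound 4 is expected to give about 500 nM, with a range from 120 nM to 2500 nM.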

Compound 4, half-maximal effective concentration: 3220 nM
The estimate for compound 4 lay 6.4-fold (0.81 log units) below the measured number, and the stated range ends below it.
By their numbers in this assay, from the lowest: compound 3; then compounds 2 and 1 (each within the scatter of the next); then compound 4.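

In this assay, the aromatic carbon para to a large group turns out to tolerate more than one level of loss: 1,1,2,2,2-pentafluoroethyl does not simply return the number to where compound 1 and compound 2 stand, since a 100-fold higher number from compound 3 to compound 4 (2.00 log units; beyond the scatter) is larger than either step that ended at compound 3. The result also shows that lacking a hydrogen-bond donor does not fix a single level here, since an 8.1-fold higher number from compound 2 to compound 4 (0.91 log units; beyond the scatter) and a 7.9-fold higher number from compound 1 to compound 4 (0.90 log units; beyond the scatter) separate compound 4 from two compounds whose groups also lack one, while those two stay within the scatter of each other. Within the data shown here, nothing measured here explains why this group raises the number so far.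

The compounds shown leave open whether the hydroxy itself or the carbon framework that carries it goes with the low number of compound 3 at 32 nM, a question that a tert-butyl group on this carbon would address. They also leave open how an amine, a carboxylic acid or a longer chain ending in a hydroxy would compare at the same place.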